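The source may hold more compounds than are shown below. What is called first, only, known or untested is meant among the compounds shown, and "the series" means these compounds.

Measured so far:
compound 1, `O=C(COc1cccc2ccccc12)N/N=C/c1ccc(O)cc1`: 60.6 ug/mL
compound 2, `O=C(COc1cccc2ccccc12)N/N=C/c1ccccc1Br`: 100 ug/mL
compound 3, `O=C(COc1cccc2ccccc12)N/N=C/c1ccccc1`: 64.5 ug/mL

In an ADME assay on HEL cells (Homo sapiens) for cytotoxicity (a higher number here means that more compound is tolerated, a lower number that less compound is tolerated), compound 3 stands second highest of the three numbers; the nearest gap is a 1.1-fold higher number from compound 1 to compound 3 (0.03 log units; within the scatter) and the furthest gap is a 1.6-fold lower number from compound 2 to compound 3 (0.19 log units; within the scatter); both lie within the scatter. Compound 4, `O=C(COc1cccc2ccccc12)N/N=C/c1ccccc1[N+](=O)[O-]`, differs from compound 3 by nitro in place of hydrogen on an aromatic carbon, on an aromatic carbon of a six-membered aromatic ring of carbon only, ortho to a large group. The step that bears on this is the reverse of a 1.6-fold lower number from compound 2 to compound 3 (0.19 log units; within the scatter), another single substituent at the same place; a 1.7-fold higher number from compound 1 to compound 2 (0.22 log units; within the scatter) also brought such a group in. Both stayed within the scatter, so for compound 4 no step beyond the scatter is expected in this assay, estimated as a 1.1-fold higher number from compound 3 to compound 4 (0.05 log units; within the scatter). Compound 4 is expected near 72 ug/mL, between 40 ug/mL and 120 ug/mL.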

Compound 4, half-maximal cytotoxic concentration: 100 ug/mL
For compound 4 the middle estimate is 1.4-fold (0.14 log units) below the measured one; the measured number falls inside the stated range.
By their numbers in this assay, from the lowest: compounds 1, 3, 2 and 4 (each within the scatter of the next).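

In this assay, nitro in place of hydrogen on the aromatic carbon ortho to a large group gives a 1.6-fold higher number from compound 3 to compound 4 (0.19 log units; within the scatter) and stays within the scatter, so a second substituent at this place, after bromo, again produces no readable step. Nitro in place of bromo gives no change at the digits printed from compound 2 to compound 4 (within the scatter) and the two groups cannot be told apart in this read-out. No supporting measurement is available to explain these results. On these data alone, whether an amine or a carboxylic acid at this same place would take the number beyond the scatter remains open.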